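This account rests on a few compounds, and the source may have more. Where it says the series, first, only, none or still open, it means among the compounds named here.

The compounds measured so far:
compound 1, `Nc1ccccc1-c1cnc(C(=O)CCCCCCc2ccccc2)o1`, 750 nM
compound 2, `O=C(CCCCCCc1ccccc1)c1ncc(-c2cccc(O)c2)o1`, 50 nM
compound 3, `Cc1cccc(-c2cnc(C(=O)CCCCCCc3ccccc3)o2)n1`, 3.3 nM

All three were tested in an assay (Rattus norvegicus) for inhibition of Fatty-acid amide hydrolase 1 (Homo sapiens); on this read-out higher numbers stand for weaker inhibition and lower numbers for stronger inhibition. Compound 1 has the highest number of the three: compound 2 is nearest, with a 15-fold lower number from compound 1 to compound 2 (1.18 log units; beyond the scatter), and compound 3 is furthest, with a 230-fold lower number from compound 1 to compound 3 (2.36 log units; beyond the scatter). Between those two, a 15-fold lower number from compound 2 to compound 3 (1.18 log units; beyond the scatter). The three share one core and differ only in the group attached to one carbon of it.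

Compound 4, `COc1ccnc(-c2cnc(C(=O)CCCCCCc3ccccc3)o2)c1`, has not yet been measured. It differs from compound 1 in a single place: 4-methoxypyridin-2-yl in place of 2-aminophenyl on an aromatic carbon. For the measured compounds named here, the step that bears most on this change is the one to compound 3, where 6-methylpyridin-2-yl replaced 2-aminophenyl at the same place and gave a 230-fold lower number from compound 1 to compound 3 (2.36 log units; beyond the scatter). Compound 4 carries 4-methoxypyridin-2-yl, also a six-membered aromatic ring with 1 hetero atom, so a large step in the same direction is expected: a 75-fold lower number from compound 1 to compound 4 (1.88 log units; beyond the scatter). The expected value for compound 4 in this assay is 10 nM, with a range from 2 nM to 60 nM.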

Compound 4, inhibition constant: 0.8 nM
For compound 4 the middle estimate is 13-fold (1.10 log units) above the measured one; the measured number lies below the stated range.
By their numbers in this assay, from the lowest: compound 4; then compound 3; then compound 2; then compound 1.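

For the compounds shown here, with a 940-fold lower number from compound 1 to compound 4 (2.97 log units; beyond the scatter), the 4-methoxypyridin-2-yl group gives the largest drop seen so far at this carbon next to the ring oxygen, showing that the 6-methyl arrangement of compound 3 is not the only pyridinyl group that works here. The two pyridinyl groups are not interchangeable, however: there is a 4.1-fold lower number from compound 3 to compound 4 (0.62 log units; beyond the scatter), a modest step but one beyond the scatter. There is also a 63-fold lower number from compound 2 to compound 4 (1.80 log units; beyond the scatter), so among these four compounds both groups with a nitrogen in the ring give lower numbers than both groups with a carbon-only ring.

Nothing measured here explains these differences. A plain pyridin-2-yl or a 4-methoxyphenyl group at this carbon would help show whether the ring nitrogen or the methoxy group counts for more.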